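Swapping ethyl for cyclopentyl on the ketone chain

The source may hold more compounds than are shown below. What is called first, only, known or untested is meant among the compounds shown, and "the series" means these compounds.

Compound 1 `CCCC(=O)c1ccc(OCCCCOc2ccc(C(=O)O)cc2C)c(C)c1O` was tested in an assay on HEK293 cells for positive allosteric modulation of metabotropic glutamate receptor 2 (Rattus norvegicus), read by thallium flux, with a stated time of 2.5 min (on this read-out lower numbers stand for an effect already at smaller amounts and higher numbers for an effect only at larger amounts of compound), and gives 104 nM. Compound 2 `Cc1c(OCCCCOc2ccc(C(=O)O)cc2F)ccc(C(=O)CC(C)C)c1O` gives 102 nM in this assay, which lies within the scatter of the number for compound 1, so the two cannot be told apart. Compound 3 `COC(=O)c1ccc(OCCCCOc2ccc(C(=O)CC(C)C)c(C)c2C)cc1` has "not determined" (no result reported) in this assay, that is, no result. Compound 1 thus stands at the higher of two numbers that are effectively equal. Compound 4 `Cc1cc(C(=O)O)ccc1OCCCCOc1ccc(C(=O)CC2CCCC2)c(O)c1C` has not yet been measured; it differs from compound 1 as follows: cyclopentyl in place of ethyl on a saturated chain carbon bound to a carbonyl carbon. Among the measured compounds shown here, no measured pair shows this change, so the step of a 1.2-fold lower number from compound 1 to compound 4 (0.06 log units; within the scatter) is expected to stay small and its direction is uncertain. Compound 4 is estimated at 90 nM, within 30 nM to 270 nM.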

Compound 4, half-maximal effective concentration: 608 nM
Estimate against measurement, compound 4: 6.8-fold (0.83 log units) below, and the stated range ends below it.
By their numbers in this assay, from the lowest: compounds 2 and 1 (each within the scatter of the next); then compound 4.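

In this assay, cyclopentyl in place of ethyl on a saturated chain carbon bound to a carbonyl carbon gives a 5.8-fold higher number from compound 1 to compound 4 (0.77 log units; beyond the scatter), so compound 4 needs a larger amount of compound for the same effect. This shows that the read-out responds to a change at this place on the ketone chain. Nothing measured here explains the rise.

Going by these compounds, whether it comes from the ring itself or from the added carbons stays open. A straight pentyl chain or a smaller cyclopropyl at this place would help separate the two.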